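Removing the Hydroxy Group from a Bromophenyl Amide

The source may hold more compounds than are shown below. What is called first, only, known or untested is meant among the compounds shown, and "the series" means these compounds.

Of the compounds shown here, three built on one shared core have been measured in an assay for inhibition of HSP60/HSP10 (Homo sapiens), with a stated time of 60 min; on this read-out lower numbers stand for stronger inhibition and higher numbers for weaker inhibition. Compound 1 `O=C(Nc1ccc(Sc2nc3ccccc3s2)cc1)c1ccccc1` gives only a limit of the assay, > 100000 nM. Compound 2 `O=C(Nc1ccc(Sc2nc3ccccc3s2)cc1)c1ccccc1O` likewise gives only a limit, > 100000 nM. For the measured compounds named here, compound 3 `O=C(Nc1ccc(Sc2nc3ccccc3s2)cc1)c1cccc(Br)c1O` gives 26000 nM, the only number among the three, since the other two results sit at the limit of > 100000 nM in this assay, at which 2 of the 3 values shown sit. Adding the hydroxy group gave a step that the two limits leave unreadable from compound 1 to compound 2, adding the bromo group on top of it gave an at least 3.8-fold lower number from compound 2 to compound 3 (0.58 log units; beyond the scatter), and the two changes together gave an at least 3.8-fold lower number from compound 1 to compound 3 (0.58 log units; beyond the scatter).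

Compound 4 `O=C(Nc1ccc(Sc2nc3ccccc3s2)cc1)c1cccc(Br)c1` has not yet been measured in this assay. It differs from compound 3 by hydrogen in place of hydroxy on an aromatic carbon. Going by the values given here, the only step that directly touches the hydroxy group is the one from compound 1 to compound 2, and it is unreadable because both values are limits, so the weight of the hydroxy group alone cannot be read from the data. Among the compounds with values here, the step from compound 2 to compound 3 shows that the bromo group carries a sizeable share of the gain, which is the one piece of evidence in favour of compound 4 keeping a measurable value. Compound 4 is therefore expected to give roughly 60000 nM, somewhere between 15000 nM and 200000 nM, with a real chance that only a limit is reported. That estimate means a 2.3-fold higher number from compound 3 to compound 4 (0.36 log units; beyond the scatter) is expected.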

Compound 4, half-maximal inhibitory concentration: > 100000 nM
Compound 4 gave a limit, no number (the forecaster's own chance of this, stated with the estimate: 40%); at least 1.6-fold (0.22 log units) between middle value and limit.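

In this assay, for the compounds shown here, taking the hydroxy group away from the 3-bromo-2-hydroxyphenyl group gave an at least 3.8-fold higher number from compound 3 to compound 4 (0.58 log units; beyond the scatter), the first readable step that touches the hydroxy group alone. Compound 4 carries the bromo group without the hydroxy group and compound 2 carries the hydroxy group without the bromo group; each gives only a limit of the assay, so among the four compounds only compound 3, which holds both groups, gives a number. The steps from compound 1 to compound 4 and from compound 2 to compound 4 cannot be read, because both ends of each sit at the same limit: the limit of > 100000 nM in this assay, at which 3 of the 4 values shown sit.

The compounds shown leave open how far compound 2 and compound 4 lie beyond that limit, so the size of the step is bounded on one side only. They also leave open whether a methoxy group or an amine in place of the hydroxy group, or chlorine in place of the bromo group, would keep a number like that of compound 3, which gives 26000 nM.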